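The compounds below may be only part of what the source reports. "The series", "measured", "known", "first", "only" and "open" are said of these compounds alone.

Three compounds that share one core and differ only in the substituted phenyl group on an aromatic nitrogen have been tested in a functional assay on PANC-1 cells (Homo sapiens) for inhibition, read by MTT assay, with a stated time of 24 h; a lower number here means a stronger inhibitor, a higher number a weaker inhibitor. Compound 1 `CC1(C)[C@H]2CC[C@]1(C)N(Cc1cn(-c3cccc(F)c3)nn1)C(=O)C2` gives 220 nM, compound 2 `CC1(C)[C@H]2CC[C@]1(C)N(Cc1cn(-c3ccc(C#N)cc3)nn1)C(=O)C2` gives 250 nM, and compound 3 `CC1(C)[C@H]2CC[C@]1(C)N(Cc1cn(-c3ccc(O)cc3)nn1)C(=O)C2` gives 100 nM. Compound 3 therefore has the lowest number of the three and is the strongest inhibitor so far.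

The next compound, compound 4 `Cc1ccc(-n2cc(CN3C(=O)C[C@@H]4CC[C@@]3(C)C4(C)C)nn2)cc1`, carries one change from compound 3: methyl in place of hydroxy on an aromatic carbon, para to a large group (methyl in place of hydroxy on an aromatic carbon). Among the measured compounds shown here, no measured step makes this exact swap, so the evidence is indirect. Placing hydroxy where cyano stood gave a 2.5-fold lower number from compound 2 to compound 3 (0.40 log units; beyond the scatter), and the change from 3-fluorophenyl to 4-hydroxyphenyl gave a 2.2-fold lower number from compound 1 to compound 3 (0.34 log units; beyond the scatter). Both steps are modest. The two compounds without hydroxy are close to each other, with a 1.1-fold higher number from compound 1 to compound 2 (0.06 log units; within the scatter).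

Compound 4 also lacks the hydroxy, so it is expected to fall near those two rather than near compound 3, although three compounds make a thin basis. In this assay, a modest rise is therefore expected, an estimated 2.0-fold higher number from compound 3 to compound 4 (0.30 log units; within the scatter). For compound 4 the expected value is 200 nM, with an estimated range of 90 nM to 450 nM.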

Compound 4, half-maximal inhibitory concentration: 270 nM
Estimate against measurement, compound 4: 1.4-fold (0.13 log units) below; low and high end bracket the measured number.
By their numbers in this assay, from the lowest: compound 3; then compounds 1, 2 and 4 (each within the scatter of the next).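

Among the compounds shown here, compound 3 and compound 4 are the first pair that differ only in the group at this place on the ring, para to a large group, and exchanging hydroxy for methyl gives a 2.7-fold higher number from compound 3 to compound 4 (0.43 log units; beyond the scatter) in this assay, even though the two groups have the same heavy-atom count. Methyl does not separate from the other groups without hydroxy, with a 1.1-fold higher number from compound 2 to compound 4 (0.03 log units; within the scatter) and a 1.2-fold higher number from compound 1 to compound 4 (0.09 log units; within the scatter), so among these four compounds only the 4-hydroxyphenyl compound stands apart and none goes against that pattern. Nothing measured here explains the difference. A hydrogen-bond donor and acceptor are counted for hydroxy alone, and the data do not tell whether they have any part in this step.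

The compounds shown leave open whether a methoxy or an amine on this same carbon would stay with compound 3 or with the other three, which would help separate the oxygen from the hydrogen it carries. They also leave open whether a hydroxy on another carbon of this ring would give a similar number, and whether the step holds in other cell lines.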